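Adding a methyl to the amine in two related series

This account rests on a few compounds, and the source may have more. Where it says the series, first, only, none or still open, it means among the compounds named here.

Compound 1, `CNCC(=O)Nc1cc(OC)ccc1C(=O)c1ccc(OC)c2c1OC(C)(C)C=C2`, is a benzophenone-type ketone carrying a methylamino-acetamide arm. In a functional assay on A2780 cells (Homo sapiens) for antiproliferative activity, read by MTT assay, with a stated time of 48 h (a higher number here means a weaker inhibitor, a lower number a stronger inhibitor), compound 1 gives 620 nM. Compound 2, `CCNCC(=O)Nc1cc(OC)ccc1C(=O)c1ccc(OC)c2c1OC(C)(C)C=C2`, differs from compound 1 by methyl in place of hydrogen on a saturated chain carbon bound to an amine nitrogen. Measured in this assay, compound 2 gives 1980 nM, and the step of a 3.2-fold higher number from compound 1 to compound 2 (0.50 log units; beyond the scatter) shows that this small addition weakened the inhibitor.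

Compound 3, `C=C(c1ccc(OC)cc1NC(=O)CNC)c1ccc(OC)c2c1OC(C)(C)C=C2`, keeps the same arm as compound 1 but on a different core; the difference between the two cores is not broken down here. In this assay compound 3 gives 210 nM, the lowest number among the three measured compounds, with its nearest neighbour compound 1 and the furthest compound 2.

Compound 4, `C=C(c1ccc(OC)cc1NC(=O)CNCC)c1ccc(OC)c2c1OC(C)(C)C=C2`, has not yet been measured. It differs from compound 3 by methyl in place of hydrogen on a saturated chain carbon bound to an amine nitrogen, the same change that was already made from compound 1 to compound 2, at the same kind of place on a saturated chain carbon bound to an amine nitrogen. The expectation for compound 4 rests on that earlier pair: because a 3.2-fold higher number from compound 1 to compound 2 (0.50 log units; beyond the scatter) was a modest loss, a step of similar size, a 3.1-fold higher number from compound 3 to compound 4 (0.49 log units; beyond the scatter), is expected here. This rests on a single earlier example only, so the expected range is kept wide. Compound 4 is therefore estimated at 650 nM, with a plausible span from 300 nM to 1500 nM.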

Compound 4, half-maximal inhibitory concentration: 1030 nM
Beside the measured number, compound 4's estimate is 1.6-fold (0.20 log units) below it; low and high end bracket the measured number.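

Changing methylamino to ethylamino on the core of compound 3 again gives a weaker inhibitor in this assay, with a 4.9-fold higher number from compound 3 to compound 4 (0.69 log units; beyond the scatter). Set beside the earlier step, the loss carries over from one core to the other, and the two step sizes cannot be told apart: the same change on two cores in this assay, a 3.2-fold higher number (0.50 log units; beyond the scatter) from compound 1 to compound 2 and a 4.9-fold higher number (0.69 log units; beyond the scatter) from compound 3 to compound 4, 1.5-fold (0.19 log units) apart, within the scatter of two such steps

For the compounds shown here, this shows only that the change behaved alike in two matched pairs in one cell assay; it does not give a general rule for other cores or other cell lines, and it does not explain why the longer group weakens these compounds.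

The compounds shown leave open whether the loss keeps growing with a longer chain such as propylamino, and how a branched isopropylamino group or a ring amine such as pyrrolidine would compare with methylamino on either core. They also leave open whether the primary amine, with a plain amino group in place of methylamino, would give a lower or a higher number, and whether the same step would hold on a third core.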